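Trimming the Aromatic Nitrogen Group Down to Methyl

This account rests on a few compounds, and the source may have more. Where it says the series, first, only, none or still open, it means among the compounds named here.

Compound 3 `CCNC(=O)n1nc(C)c(-c2ccc(Cl)c(Cl)c2)c1N` was tested in an assay on Sf9 cells for inhibition of inhibitor of nuclear factor kappa-B kinase subunit epsilon (Homo sapiens), read by ADP-Glo, with a stated time of 60 min; on this read-out lower numbers stand for stronger inhibition and higher numbers for weaker inhibition. In this assay compound 3 gives > 100000 nM, which is a limit of the assay rather than a number. Its two neighbours share the same core. Compound 1 `Cc1nn(C(=O)C2CCC2)c(N)c1-c1ccc(Cl)c(Cl)c1` gives > 100000 nM in this assay, also a limit. Compound 2 `Cc1nn(C(=O)C2CCCC2)c(N)c1-c1ccc(Cl)c(Cl)c1` gives > 100000 nM in this assay, again a limit. The steps among them, a step that the two limits leave unreadable from compound 1 to compound 2, a step that the two limits leave unreadable from compound 1 to compound 3 and a step that the two limits leave unreadable from compound 2 to compound 3, are therefore unreadable in size because of the limit of > 100000 nM in this assay, at which 3 of the 3 values shown sit. Compound 4 `Cc1nn(C)c(N)c1-c1ccc(Cl)c(Cl)c1` differs from compound 3 by methyl in place of ethylcarbamoyl on an aromatic nitrogen. None of the measured steps alters the group on the aromatic nitrogen in this way, so nothing shown tells how large the move will be or in which direction. With all three known compounds at the limit, compound 4 is expected to stay close to it, and the expected step that the limit leaves unreadable from compound 3 to compound 4 means no change beyond the scatter. The estimate for compound 4 in this assay is 150000 nM, ranging from 30000 nM to 1000000 nM.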

Compound 4, half-maximal inhibitory concentration: > 100000 nM
Compound 4: only a limit was reported; the forecaster's own chance of this, stated with the estimate: 80%; the middle value lies beyond the limit too.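

Compound 4 reaches the same limit as compound 1, compound 2 and compound 3, so none of the steps to compound 4 can be read in size, because all the compounds sit at one limit: the limit of > 100000 nM in this assay, at which 4 of the 4 values shown sit. The compounds shown leave open whether any group on the aromatic nitrogen gives a readable value in this assay.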